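The source may hold more compounds than are shown below. What is called first, only, known or untested is meant among the compounds shown, and "the series" means these compounds.

In a functional assay on CCRF-CEM cells (Homo sapiens) for inhibition, read by cell counting, with a stated time of 72 h (on this read-out lower numbers stand for stronger inhibition and higher numbers for weaker inhibition), compound 1 (`CCN(CC)CN1C(=O)/C(=N/NC(=S)Nc2ccc(Cl)cc2)c2ccccc21`) gives 10000 nM and compound 2 (`CCN(CC)CN1C(=O)/C(=N/NC(=S)Nc2ccc(C)cc2)c2ccccc21`) gives 12000 nM, so the two stand level within the scatter. Compound 3 (`CCN(CC)CN1C(=O)/C(=N/NC(=S)Nc2ccc(Cl)cc2)c2cc(Cl)ccc21`) is compound 1 with one change to the shared core: chloro in place of hydrogen on an aromatic carbon. Among the measured compounds shown here, the only measured step, a 1.2-fold higher number from compound 1 to compound 2 (0.08 log units; within the scatter), swaps methyl for chloro at a different place, so it is a weak guide to this new chloro. It does show a small step, and no step beyond the scatter is expected here. The expected change is a 1.3-fold lower number from compound 1 to compound 3 (0.10 log units; within the scatter). Compound 3 is estimated at 8000 nM, with an expected range of 3000 nM to 18000 nM.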

Compound 3, half-maximal inhibitory concentration: > 125000 nM
Compound 3 gave a limit, no number; the forecaster's own chance of this, stated with the estimate: 8%; middle value at least 15-fold (1.19 log units) from the limit.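

In this assay, chloro in place of hydrogen on this aromatic carbon of the shared core gives an at least 12-fold higher number from compound 1 to compound 3 (1.09 log units; beyond the scatter), whereas the earlier swap of methyl for chloro elsewhere gave only a 1.2-fold higher number from compound 1 to compound 2 (0.08 log units; within the scatter). So this position responds strongly to a single added atom, in the direction of weaker inhibition, something the first two compounds could not show. Compound 3 gives a limit, not a number: the limit of > 125000 nM in this assay, at which 1 of the 3 values shown sits.

Going by these compounds, the true size of the step therefore stays unknown. On these data alone, whether fluoro, methoxy or an amine at this same position would cost as much also remains open.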